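Notes on the step from compound 3 to compound 4

This account rests on a few compounds, and the source may have more. Where it says the series, first, only, none or still open, it means among the compounds named here.

Values from a functional assay on MDA-N cells (Homo sapiens) (on this read-out lower numbers stand for stronger inhibition of growth and higher numbers for weaker inhibition of growth), for the measured compounds follow
- compound 1 `COc1ccc(-c2cc(O)c3cccnc3n2)cc1` gives 20900 nM
- compound 2 `COc1ccc(-c2cc(O)c3c(C)cc(C)nc3n2)cc1` gives 33100 nM
- compound 3 `COc1ccccc1-c1cc(O)c2ccc(C)nc2n1` gives 20000 nM

Compound 3 at 20000 nM lies within the scatter of both compound 1 and compound 2, so the numbers set no order among the three. The unmeasured compound 4 `COc1ccccc1-c1cc(O)c2cccnc2n1` differs from compound 3 in one place: hydrogen in place of methyl on an aromatic carbon, next to the ring nitrogen. Among the measured compounds shown here, no measured pair differs in one place only, so no direct step informs this change. Compound 2 at 33100 nM carries methyl groups on the core and compound 1 at 20900 nM carries none, yet these two values also lie within the scatter of each other. On that basis, the expected size in this assay of a 1.1-fold higher number from compound 3 to compound 4 (0.02 log units; within the scatter) is none beyond the scatter, with no direction favoured. Compound 4 is estimated at 21000 nM with an expected range of 12000 nM to 38000 nM in this read-out.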

Compound 4, concentration for 50% growth inhibition: 20000 nM
Beside the measured number, compound 4's estimate is 1.1-fold (0.02 log units) above it; low and high end bracket the measured number.
By their numbers in this assay, from the lowest: compounds 3, 4, 1 and 2 (each within the scatter of the next).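

In this assay, among the compounds shown here, hydrogen in place of methyl on an aromatic carbon, next to the ring nitrogen, gives no change at the digits printed from compound 3 to compound 4 (within the scatter), the first comparison that isolates a single place. For the compounds shown here, with compound 3 as the background, the methyl at this position makes no readable difference in this read-out, which the earlier compounds could not show, since none of them differed from another in one place only. Nothing available gives a reason for this flat step.

As far as these compounds go, whether an amine, a carboxylic acid or a longer chain at this position would move the number beyond the scatter remains open. The finding also rests on a single pair, leaving open whether the same change would read alike on another background.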